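Carboxyphenyl for chlorophenyl on the shared core

This account rests on a few compounds, and the source may have more. Where it says the series, first, only, none or still open, it means among the compounds named here.

Three compounds of this series have numbers in an assay on microsomes from brain for inhibition of Fatty-acid amide hydrolase 1 (Rattus norvegicus), read by fluorescence and HPLC, with a stated time of 60 min; on this read-out higher numbers stand for weaker inhibition and lower numbers for stronger inhibition. Compound 1 `CCCCCCCCc1ccc(OCC(=O)Cn2nnc(SC)n2)cc1` gives 31 nM. Compound 2 `CCCCCCCCc1ccc(OCC(=O)Cn2nnc(-c3ccccn3)n2)cc1` gives 18 nM; the step of a 1.7-fold lower number from compound 1 to compound 2 (0.24 log units; within the scatter) stays within the scatter. Compound 3 `CCCCCCCCc1ccc(OCC(=O)Cn2nnnc2-c2ccccc2Cl)cc1` gives 4600 nM, the highest number of the three, standing beyond the scatter from both compound 1 and compound 2.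

Compound 4 `CCCCCCCCc1ccc(OCC(=O)Cn2nnnc2-c2cccc(C(=O)O)c2)cc1` has not been measured. It differs from compound 3 by 3-carboxyphenyl in place of 2-chlorophenyl on an aromatic carbon. Among the compounds with values here, no measured step exchanges a group on the aromatic carbon of the five-membered aromatic ring with 4 nitrogen where compound 3 and compound 4 differ. Within the data shown here, the only measured step, a 1.7-fold lower number from compound 1 to compound 2 (0.24 log units; within the scatter), concerns another arrangement of the core and was within the scatter, so it gives no direction for this exchange. Compound 4 is therefore expected to stay close to compound 3, an expected step of a 1.3-fold higher number from compound 3 to compound 4 (0.12 log units; within the scatter). The estimate for compound 4 is 6000 nM, with a range from 1500 nM to 25000 nM.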

Compound 4, half-maximal inhibitory concentration: 1800 nM
Beside the measured number, compound 4's estimate is 3.3-fold (0.52 log units) above it, and the stated range covers the measured number.
By their numbers in this assay, from the lowest: compounds 2 and 1 (each within the scatter of the next); then compound 4; then compound 3.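

In this assay, the aromatic carbon between two ring nitrogen atoms responds to the exchange of its aryl group: 3-carboxyphenyl in place of 2-chlorophenyl gives a 2.6-fold lower number from compound 3 to compound 4 (0.41 log units; beyond the scatter). Within the data shown here, this is the first step at this position to pass the scatter, although it is modest in size, and it shows that a carboxylic acid on the phenyl ring is tolerated here with no loss of inhibition. No supporting measurement is available to explain the step.

The exchange removes the chlorine and adds the carboxylic acid in one move, and the group's place on the phenyl ring changes with it, so the contribution of each remains unresolved. Unsubstituted phenyl at this carbon, or the methyl ester of the carboxylic acid, would separate these contributions and test whether the acid hydrogen matters.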